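Vero cell tolerance across the aryl ether series

A few compounds are considered here, and "the series" means these few. Any claim that something is new, unique, unknown or untested is made for them only; others in the source may bear on it.

Among the compounds with values here, compound 1 `C=C1CC[C@H]2[C@@](C)(CCC(=O)[C@@]2(C)COC(C)=O)[C@@H]1C/C=C1/C(=O)OC[C@@H]1Oc1c(Cl)cc(Cl)c2cccnc12` and compound 2 `C=C1CC[C@@H]2[C@](C)(CO)[C@H](O)CC[C@@]2(C)[C@@H]1C/C=C1/C(=O)OC[C@H]1Oc1c(Cl)cc(Cl)c2cccnc12` share a core but differ in several places at once, so no single step joins them. In a toxicity assay on Vero cells (Chlorocebus sabaeus) for cytotoxicity, with a stated time of 48 h (a higher number here means that more compound is tolerated, a lower number that less compound is tolerated), compound 1 gives 57400 nM, and in this assay compound 2 gives 82500 nM. Compound 2 carries the higher of the two numbers, yet the gap to compound 1 lies within the scatter, so the two tolerances read as alike and no order is claimed.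

Compound 3 `C=C1CC[C@@H]2[C@](C)(CO)[C@H](O)CC[C@@]2(C)[C@@H]1C/C=C1/C(=O)OC[C@H]1Oc1cccnc1[N+](=O)[O-]` keeps the core of compound 2 and differs from it in one place: 2-nitropyridin-3-yl in place of 5,7-dichloroquinolin-8-yl on an oxygen on a saturated carbon. Within the data shown here, no measured pair in this set differs in one place only, so there is no measured step on which to size this change.

The expectation is that compound 3 stays close to compound 2, with a step (a 1.1-fold lower number from compound 2 to compound 3 (0.04 log units; within the scatter)) expected to lie within the scatter rather than beyond it in either direction. For compound 3 the estimated value in this assay is 75000 nM, with an expected range from 30000 nM to 160000 nM.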

Compound 3, half-maximal cytotoxic concentration: 37700 nM
The estimate for compound 3 lay 2.0-fold (0.30 log units) above the measured number; the measured number falls inside the stated range.
By their numbers in this assay, from the lowest: compounds 3, 1 and 2 (each within the scatter of the next, the first and the last beyond it).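

Within the data shown here, the exchange of 5,7-dichloroquinolin-8-yl for 2-nitropyridin-3-yl on an oxygen on a saturated carbon gives, in this assay, a 2.2-fold lower number from compound 2 to compound 3 (0.34 log units; beyond the scatter), which is the first step that can be read at a single place. The group on this oxygen therefore has a bearing on how much compound the cells tolerate, although the effect is modest and the shared core is unchanged. No measurement available here explains the step, and the exchange alters several features at once: the six-membered aromatic ring of carbon only and the chlorine atoms leave, while a nitro-bearing pyridine enters.

With one exchange at this position, the contributions of the lost carbon ring, the lost chlorine atoms and the new nitro group cannot be separated, and a single step gives no trend. From the compounds shown here alone, a plain pyridin-3-yl or a 2-aminopyridin-3-yl on the same oxygen would help to separate them, and it remains open whether 2-nitropyridin-3-yl would give a step of similar size on the core of compound 1.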